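Cyano for fluoro at two different places: working notes

This account rests on a few compounds, and the source may have more. Where it says the series, first, only, none or still open, it means among the compounds named here.

All numbers come from a functional assay on cells for agonist activity at Free fatty acid receptor 1 (Mus musculus), read by FLIPR and calcium flux, with a stated time of 5 min; a higher number here means that more compound is needed for the effect, a lower number that less compound is needed.

compound 1 `Cc1nn(-c2ccccn2)c2cc(-c3ccc(CCC(=O)O)cc3C#N)ccc12`: 6100 nM
compound 2 `Cc1nn(-c2ccccn2)c2cc(-c3ccc(CCC(=O)O)cc3F)ccc12`: 1500 nM
compound 3 `O=C(O)CCc1ccc(-c2cc(F)c3cnn(-c4ccccn4)c3c2)cc1`: 2600 nM

Compound 2 and compound 1 differ in one place: cyano in place of fluoro on an aromatic carbon. In this assay this gave a 4.1-fold higher number from compound 2 to compound 1 (0.61 log units; beyond the scatter).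

Compound 3 carries a different core; the difference between the cores of compound 2 and compound 3 is not broken down here. Compound 3 and compound 2 lie within the usual scatter of each other, so no order between them is read. Compound 1 lies beyond the scatter from compound 3, with the higher number.

Compound 4 `N#Cc1cc(-c2ccc(CCC(=O)O)cc2)cc2c1cnn2-c1ccccn1` is not yet measured. It differs from compound 3 by cyano in place of fluoro on an aromatic carbon. The place is not the same as in the step from compound 2 to compound 1: there the carbon was ortho to a large group and meta to a 2-carboxyethyl group, here it is part of a fused or bridged system of two rings, ortho to a fused ring, meta to a fused ring and meta to a large group. It is the same kind of change, not the same change, and it occurs twice in all among these compounds.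

Among the compounds with values here, the step is expected to be a 3.1-fold higher number from compound 3 to compound 4 (0.49 log units; beyond the scatter), resting on a 4.1-fold higher number from compound 2 to compound 1 (0.61 log units; beyond the scatter) as the only measured instance; the place differs, so the range is set wide. For compound 4 the estimate in this assay is 8000 nM, expected between 2500 nM and 25000 nM.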

Compound 4, half-maximal effective concentration: 19000 nM
For compound 4 the middle estimate is 2.4-fold (0.38 log units) below the measured one, within the range that was stated.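

Cyano in place of fluoro on an aromatic carbon, now at a place that is part of a fused or bridged system of two rings, gave in this assay a 7.3-fold higher number from compound 3 to compound 4 (0.86 log units; beyond the scatter). Set beside the earlier step, the new one points the same way and cannot be told apart from it in size: the same change on two cores in this assay, a 4.1-fold higher number (0.61 log units; beyond the scatter) from compound 2 to compound 1 and a 7.3-fold higher number (0.86 log units; beyond the scatter) from compound 3 to compound 4, 1.8-fold (0.25 log units) apart, within the scatter of two such steps. For these two cores, the change therefore carried over in direction and, within the scatter, in size, but two instances at two different places show neither that the size is fixed nor that the same step would appear on a further core, and they give no reason for the higher numbers.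

The compounds shown leave open whether other groups at the same aromatic carbon, such as an amine, a methoxy group or a trifluoromethyl group, would stay close to fluoro or move as far as cyano. On these data alone, all four compounds also carry the same 2-carboxyethyl group, so it remains open whether the step would hold with a longer chain or an amide in its place.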